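The compounds below may be only part of what the source reports. "The series", "measured", "known", "first", "only" and "open" are said of these compounds alone.

In a functional assay on LNCaP C4-2B cells (Homo sapiens) for cytotoxicity, read by MTT assay, with a stated time of 72 h (on this read-out higher numbers stand for weaker inhibition and lower numbers for stronger inhibition), compound 1 `COc1cc(/C=C/C(O)=C/C(=O)/C=C/C2=C(C)CCCC2(C)C)ccc1O` gives 44300 nM and compound 3 `COc1cc(/C=C(\C(=O)/C=C/C2=C(C)CCCC2(C)C)C(=O)/C=C/c2cc(OC)c(O)c(OC)c2)cc(OC)c1O` gives 8500 nM. For compound 2 `COc1ccc(/C=C/C(O)=C/C(=O)/C=C/C2=C(C)CCCC2(C)C)cn1` the entry in this assay reads "not determined" (no result reported), so it has no place on these numbers. Compound 4 `COc1ccc(/C=C/C(O)=C/C(=O)/C=C/C2=C(C)CCCC2(C)C)cc1O` has yet to be measured in this assay. The structural change that leads to it from compound 2 is 3-hydroxy-4-methoxyphenyl in place of 6-methoxypyridin-3-yl on a double-bonded chain carbon bound to a double-bonded chain carbon. For the measured compounds named here, with no number at its starting end, this step has no measured size, and no other step between measured compounds is available as a guide. The closest reference is compound 1 at 44300 nM, and compound 4 is expected to differ from that figure by no more than the usual scatter in this assay, with no direction favoured. The half-maximal inhibitory concentration of compound 4 is estimated at 35000 nM, with an expected range from 15000 nM to 80000 nM.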

Compound 4, half-maximal inhibitory concentration: 23100 nM
Compound 4: the middle estimate sits 1.5-fold (0.18 log units) above what was measured; measured number inside the range.
By their numbers in this assay, from the lowest: compound 3; then compounds 4 and 1 (each within the scatter of the next).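

In this assay, putting 3-hydroxy-4-methoxyphenyl in place of 4-hydroxy-3-methoxyphenyl on a double-bonded chain carbon bound to a double-bonded chain carbon gives a 1.9-fold lower number from compound 1 to compound 4 (0.28 log units; within the scatter). For the compounds shown here, this is the first step that can be read at this position, and it shows that this assay does not separate the two arrangements of hydroxy and methoxy on the phenyl group. Nothing available explains the result or bears on it.

As far as these compounds go, compound 2 has no number in this assay, so the step from it to compound 4 cannot be read, and the effect of 6-methoxypyridin-3-yl at this position remains unknown. The compounds shown also leave open what an amine or a carboxylic acid in place of the hydroxy group on this phenyl group would do to the number.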